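The source may hold more compounds than are shown below. What is called first, only, known or untested is meant among the compounds shown, and "the series" means these compounds.

Among the measured compounds shown here, in a functional assay on cells (Panel NCI-60 (60 carcinoma cell lines), Homo sapiens) for inhibition, read by colorimetric assay, with a stated time of 3 days (on this read-out lower numbers stand for stronger inhibition of growth and higher numbers for weaker inhibition of growth), compound 1 (`COc1ccc(-c2cnc(NC(=O)CCCCCCNC(=O)C(O)(O)C(F)(F)F)s2)cc1`) gives 8510 nM as the only number in this small set. Compound 2 (`COc1ccc(NC(=O)CCCCCCNC(=O)C(O)(O)C(F)(F)F)cc1`) stands without a single number, its result being "not determined" (no result reported) in this test, so it offers no baseline of its own. The structural change is 1,3-benzothiazol-2-yl in place of 4-methoxyphenyl on an amide-type nitrogen on going from compound 2 to compound 3 (`O=C(CCCCCCNC(=O)C(O)(O)C(F)(F)F)Nc1nc2ccccc2s1`), that is, 1,3-benzothiazol-2-yl in place of 4-methoxyphenyl on an amide-type nitrogen. No measured step links any of these compounds, so the size of this change cannot be read from the data. In this assay a moderate step toward weaker inhibition of growth is expected, resting only on compound 1 at 8510 nM as the sole anchor and only a little beyond the usual scatter. The estimate for compound 3 is 18000 nM (expected range 7000 nM to 50000 nM) on this read-out.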

Compound 3, concentration for total growth inhibition: 21400 nM
Compound 3: middle estimate off by 1.2-fold (0.08 log units), on the low side; the measured number falls inside the stated range.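

No step can be read from this result: compound 3 pairs by a single change only with compound 2, which has no number in this assay. On these data alone, what swapping 4-methoxyphenyl for 1,3-benzothiazol-2-yl does to growth inhibition stays open. No supporting evidence bears on the result.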